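Ester versus acid in a cinnamate series: cytotoxicity notes

The source may report more compounds than this note shows. Statements on the series, on what has been measured and on what is new or still open speak of the compounds shown alone.

Measured compounds, read-out in a functional assay on EA.hy 926 cells (Homo sapiens) for cytotoxicity, read by MTT assay, with stated times of 24 h and 12 h, tested at 25 uM; on this read-out lower numbers stand for a weaker effect and higher numbers for a stronger effect at the one concentration tested:
compound 1, `COc1ccc(/C=C/C(=O)O)c(OC(=O)c2nc(C)c(C)nc2C)c1`, gives -52.1%
compound 2, `CCOC(=O)/C=C/c1ccc(OC)cc1OC(=O)c1nc(C)c(C)nc1C`, gives 16.9%
compound 3, `COc1cc(/C=C/C(=O)O)cc(OC)c1OC(=O)c1nc(C)c(C)nc1C`, gives 24%

Compound 1 and compound 2 share a core and differ in one place, (ethyl in place of hydrogen on an oxygen next to a carbonyl group). In this assay, going by the values given here, this change gives a number 69 percentage points higher from compound 1 to compound 2 (beyond the scatter), the only single-point step measured so far.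

Compound 3 rests on another core; the difference between the core of compound 1 and the core of compound 3 is not broken down here. In this assay compound 3 and compound 2 sit within the usual scatter of each other, while compound 3 stands beyond the scatter from compound 1.

Compound 4, `CCOC(=O)/C=C/c1cc(OC)c(OC(=O)c2nc(C)c(C)nc2C)c(OC)c1`, has not yet been measured. It differs from compound 3 by ethyl in place of hydrogen on an oxygen next to a carbonyl group, which is the same change, at the same kind of place, as that from compound 1 to compound 2.

For compound 4 in this assay the expected step is a number 26 percentage points higher from compound 3 to compound 4 (beyond the scatter), in the same direction as the measured one but smaller, because compound 3 already gives 24% whereas compound 1 starts from -52.1%; one measured pair is a thin basis, so the range is kept wide. Compound 4 is therefore estimated at 50%, expected to fall between 15% and 85%.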

Compound 4, a percentage reported as activity, at one concentration (the size of the read-out at that concentration, not a potency): 20.9%
Beside the measured number, compound 4's estimate is 29.1 percentage points above it; measured number inside the range.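

Replacing carboxy with ethoxycarbonyl on the core of compound 3 gives a number 3.1 percentage points lower from compound 3 to compound 4 (within the scatter) in this assay, so on this core the change leaves the read-out within the usual scatter. The change therefore does not carry its effect over from one core to the other, and the two measured steps differ clearly: the same change on two cores in this assay, a number 69 percentage points higher (beyond the scatter) from compound 1 to compound 2 and a number 3.1 percentage points lower (within the scatter) from compound 3 to compound 4, 72.1 percentage points apart, beyond the scatter of two such steps. Going by these compounds alone, this shows that the large step on the core of compound 1 cannot be treated as a general value for this change, but with only two matched pairs, it does not show which difference between the two cores goes with the different outcome, nor how the change would behave on any third core.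

The compounds shown leave open whether the same core dependence holds for other replacements of the carboxy group, such as a methyl ester, an ester with a longer chain or an amide. They also leave open how the two cores respond when the methoxy groups are replaced by other groups such as a halogen or an amine, and whether the gap between the steps persists at other concentrations in this assay.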